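This account rests on a few compounds, and the source may have more. Where it says the series, first, only, none or still open, it means among the compounds named here.

Measured in an ADME assay on MT4 cells (Homo sapiens) for cytotoxicity, read by MTT assay, with a stated time of 5 days; a lower number here means that less compound is tolerated, a higher number that more compound is tolerated:
- Compound 1 `Cc1cc(OCC(=O)Nc2ccc(F)cc2)nc(Nc2ccc(C#N)cc2)n1`: > 331000 nM (a limit of the assay, not a number)
- Compound 2 `Cc1cc(OCC(=O)Nc2ccc(Cl)cc2)nc(Nc2ccc(C#N)cc2)n1`: 2630 nM

Going by the values given here, compound 2, at 2630 nM, holds the only true number so far. Compound 3 `Cc1cc(OCC(=O)Nc2ccc(Br)cc2)nc(Nc2ccc(C#N)cc2)n1` carries bromo in place of chloro on an aromatic carbon. Among the compounds with values here, the one measured step that bears on this is also a halogen exchange, an at least 120-fold lower number from compound 1 to compound 2 (2.09 log units; beyond the scatter), which is large and beyond the scatter. Since that single step starts from a limit, it fixes no size, and the change in this assay is expected to stay within the scatter, with a slight lean to a lower number. The estimated step is a 1.3-fold lower number from compound 2 to compound 3 (0.12 log units; within the scatter). For compound 3 the expected value is 2000 nM, with an estimated range of 400 nM to 20000 nM.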

Compound 3, half-maximal cytotoxic concentration: 930 nM
Compound 3: middle estimate off by 2.2-fold (0.33 log units), on the high side; low and high end bracket the measured number.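

In this assay, going by these compounds alone, the change at this aromatic carbon gives a 2.8-fold lower number from compound 2 to compound 3 (0.45 log units; beyond the scatter), the first step here with a fixed size, so even the exchange of chloro for bromo registers beyond the scatter. Across the three compounds the number falls from fluoro through chloro to bromo, with an at least 350-fold lower number from compound 1 to compound 3 (2.55 log units; beyond the scatter) exceeding an at least 120-fold lower number from compound 1 to compound 2 (2.09 log units; beyond the scatter). Both of those steps start from a limit of the assay and have no fixed size: the limit of > 331000 nM in this assay, at which 1 of the 3 values shown sits.

As far as these compounds go, whether iodo would continue this order remains open. So does how hydrogen, methyl or methoxy would compare at this place.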